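Swapping the aryl sulfonyl group in a glutamide series

This account rests on a few compounds, and the source may have more. Where it says the series, first, only, none or still open, it means among the compounds named here.

Compounds measured so far:
- compound 1, `CCCCCNC(=O)CCC(NS(=O)(=O)c1ccc(Cl)c(Cl)c1)C(=O)NCCCCC`: 20.8%
- compound 2, `O=C(CCC(NS(=O)(=O)c1ccc(Cl)c(Cl)c1)C(=O)NC1CCCCC1)NC1CCCCC1`: 24%
- compound 3, `CCCCCNC(=O)CCC(NS(=O)(=O)c1cc(C)ccc1Cl)C(=O)NCCCCC`: 14.7%

Three sulfonamides have been tested in a functional assay on IMR-32 cells (Homo sapiens) for cytotoxicity, read by MTT assay, tested at 60 ug/mL; on this read-out lower numbers stand for less inhibition and higher numbers for more inhibition at the one concentration tested (going by the name of the read-out). Compound 1 carries two pentyl amides on its core, and in this assay compound 1 gives 20.8%. Compound 2 carries two cyclohexyl amides instead; how its core differs from that of compound 1 is not broken down here. In this assay compound 2 gives 24%, and compound 3 gives 14.7%. All three readings lie close to one another.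

Compound 3 is related to compound 1 by one change, (2-chloro-5-methylphenyl in place of 3,4-dichlorophenyl on a sulfonyl sulfur), which produced a number 6.1 percentage points lower from compound 1 to compound 3 (within the scatter).

Compound 4, `Cc1ccc(Cl)c(S(=O)(=O)NC(CCC(=O)NC2CCCCC2)C(=O)NC2CCCCC2)c1`, has not yet been measured. It stands to compound 2 exactly as compound 3 stands to compound 1: the change is 2-chloro-5-methylphenyl in place of 3,4-dichlorophenyl on a sulfonyl sulfur. Since the place of the change reads the same in both pairs, this is the same change applied on the cyclohexyl-amide core rather than on the pentyl-amide core.

Among the compounds with values here, the expectation for compound 4 therefore rests on the single earlier instance of this change, which gave a number 6.1 percentage points lower from compound 1 to compound 3 (within the scatter). On that basis the step from compound 2 to compound 4 is estimated at a number 6 percentage points lower from compound 2 to compound 4 (within the scatter). Within the data shown here, compound 4 is accordingly expected to give about 18% in this assay, with a plausible range from 8% to 28%, a range that reflects the single precedent and the scatter of this kind of reading.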

Compound 4, a percentage reported as inhibition, at one concentration (the size of the read-out at that concentration, not a potency): 49.7%
Beside the measured number, compound 4's estimate is 31.7 percentage points below it; measured number outside the range, above it.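

In this assay, putting 2-chloro-5-methylphenyl in place of 3,4-dichlorophenyl on the sulfonyl sulfur of the cyclohexyl-amide core gave a number 25.7 percentage points higher from compound 2 to compound 4 (beyond the scatter), a result that does not repeat what the same change did on the pentyl-amide core. Set side by side, the two instances disagree: the same change on two cores in this assay, a number 6.1 percentage points lower (within the scatter) from compound 1 to compound 3 and a number 25.7 percentage points higher (beyond the scatter) from compound 2 to compound 4, 31.8 percentage points apart, beyond the scatter of two such steps. Within the data shown here, this shows that, for these two cores, the step seen on one did not carry over to the other, so the effect of this change on the reading depends on the core that bears it; it does not show what in the two cores sets them apart, and it rests on only two pairs of compounds, each read at a single concentration, so it gives no potency and no general rule for the series.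

The compounds shown leave open whether a core with other amides, such as a propyl amide or a benzyl amide, would follow the pentyl pair, the cyclohexyl pair or neither. They also leave open how other groups on the sulfonyl sulfur, such as an unsubstituted phenyl or a 4-methoxyphenyl, would behave on either core.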